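The source may report more compounds than this note shows. Statements on the series, on what has been measured and on what is new or still open speak of the compounds shown alone.

Working notes on the series. All three measured compounds share one core: compound 1 is `O=C(/C=C/c1ccc2c(c1)B(O)OC2)c1cccs1`, compound 2 is `Cc1ccc(C(=O)/C=C/c2ccc3c(c2)B(O)OC3)cc1` and compound 3 is `CCc1ccc(C(=O)/C=C/c2ccc3c(c2)B(O)OC3)cc1`. In a functional assay on SK-OV-3 cells (Homo sapiens) for cytotoxicity, read by MTT assay, with a stated time of 48 h (a lower number here means a stronger inhibitor, a higher number a weaker inhibitor), compound 1 gives 10400 nM, the highest number of the three; compound 2 gives 3700 nM and compound 3 gives 4400 nM. Among the measured compounds shown here, the only change so far at the carbonyl carbon is a 2.8-fold lower number from compound 1 to compound 2 (0.45 log units; beyond the scatter), whereas a 1.2-fold higher number from compound 2 to compound 3 (0.08 log units; within the scatter), a change on the saturated chain carbon, stays within scatter.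

Compound 4 is `Cc1cccc(C(=O)/C=C/c2ccc3c(c2)B(O)OC3)c1`. It differs from compound 1 by 3-methylphenyl in place of thiophen-2-yl on a carbonyl carbon. This closely parallels the measured change from compound 1 to compound 2, so a lowering of similar, modest size is expected: a 2.3-fold lower number from compound 1 to compound 4 (0.36 log units; beyond the scatter). Compound 4 is thus estimated at 4500 nM, with a range from 2200 nM to 9500 nM.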

Compound 4, half-maximal inhibitory concentration: 2900 nM
Beside the measured number, compound 4's estimate is 1.6-fold (0.19 log units) above it; the measured number falls inside the stated range.
By their numbers in this assay, from the lowest: compounds 4, 2 and 3 (each within the scatter of the next); then compound 1.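

In this assay the lower number on leaving thiophen-2-yl is not confined to 4-methylphenyl: 3-methylphenyl on the carbonyl carbon also gives a 3.6-fold lower number from compound 1 to compound 4 (0.55 log units; beyond the scatter). Exchanging 4-methylphenyl for 3-methylphenyl gives a 1.3-fold lower number from compound 2 to compound 4 (0.11 log units; within the scatter), so the two groups cannot be told apart in this assay. No evidence bearing on either step is available.

Open, as far as these compounds go, is whether the methyl contributes at all. A plain phenyl, or a phenyl carrying an amine or a carboxylic acid instead of the methyl, on the shared core would address that.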